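This account rests on a few compounds, and the source may have more. Where it says the series, first, only, none or still open, it means among the compounds named here.

Three compounds sharing one core have been run in a functional assay on HCT-116 cells (Homo sapiens) for antiproliferative activity, read by MTT assay, with a stated time of 72 h; a lower number here means a stronger inhibitor, a higher number a weaker inhibitor. Compound 1 `COc1cc(CCc2cccc(Cl)c2Cl)cc(OC)c1O` gives 8780 nM in this assay. Compound 2 `COc1cc(CCc2cccc(F)c2)cc(OC)c1O` gives 7570 nM in this assay, and compound 3 `COc1ccc(CCc2ccccc2Cl)cc1OC` gives 6160 nM in this assay. Compound 2 holds the second highest of these three numbers, yet its gap to compound 1 and its gap to compound 3 both lie within the usual scatter of repeated measurements, so the three compounds cannot be ranked against one another on these results.

Compound 4 `COc1cc(CCc2ccccc2)cc(OC)c1O` has not yet been measured in this assay. It differs from compound 2 in a single place: hydrogen in place of fluoro on an aromatic carbon. For the measured compounds named here, no two measured compounds differ from each other in only one place, so there is no measured step that shows what such a change does here. The three measured values sit close together, and the change itself is a small one, so the step from compound 2 to compound 4 is expected to be no larger than the scatter, in either direction, and is estimated as a 1.1-fold higher number from compound 2 to compound 4 (0.05 log units; within the scatter). Compound 4 is therefore expected to give about 8500 nM in this assay, with a range from 4500 nM to 17000 nM.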

Compound 4, half-maximal inhibitory concentration: 530 nM
Estimate against measurement, compound 4: 16-fold (1.21 log units) above; measured number outside the range, below it.
By their numbers in this assay, from the lowest: compound 4; then compounds 3, 2 and 1 (each within the scatter of the next).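

In this assay, hydrogen in place of fluoro on an aromatic carbon gives a 14-fold lower number from compound 2 to compound 4 (1.15 log units; beyond the scatter) and so provides the first measured step across a single change. For the compounds shown here, this shows that the place on the six-membered aromatic ring of carbon only, meta to a large group, is far from indifferent: losing one heavy atom, a fluorine, moves the number well beyond the usual scatter, a sensitivity that the earlier compounds could not reveal, as no two of them differ in only one place. Nothing available here explains why this step is so large.

From the compounds shown here alone, what remains open is whether hydrogen is especially favourable at this place or fluoro especially unfavourable, a question that a methyl group, an amine or a nitrile at the same carbon could help to settle. Going by these compounds, it is also open whether the same swap would produce a step of similar size at other carbons of this ring, or on a ring that also carries chloro, since a single pair of compounds cannot establish a general rule.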